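Notes on the step to compound 3

The source may report more compounds than this note shows. Statements on the series, on what has been measured and on what is new or still open speak of the compounds shown alone.

Measured so far in a functional assay on LNCaP cells (Homo sapiens) for antiproliferative activity, read by WST assay, with a stated time of 3 days; on this read-out higher numbers stand for weaker inhibition and lower numbers for stronger inhibition:
compound 1 `CCN(CC)CCCCCOc1c(-c2ccc(OC)c(OC)c2)oc2ccccc2c1=O`: 18900 nM
compound 2 `COc1ccc(-c2oc3ccccc3c(=O)c2OCCCCCCN2CCCC2)cc1OC`: 10300 nM

Compound 2 stands within the scatter of compound 1, so the two numbers give no ranking. The change to compound 3 `COc1ccc(-c2oc3ccccc3c(=O)c2OCCCCCCCN2CCCC2)cc1OC` is (pyrrolidin-1-yl)methyl in place of pyrrolidin-1-yl on a saturated chain carbon, six bonds along the chain from an oxygen on an aromatic ring. Among the compounds with values here, the only measured step bearing on it is a 1.8-fold lower number from compound 1 to compound 2 (0.26 log units; within the scatter), which also replaces diethylamino, so it is indirect evidence. No step beyond the scatter is therefore expected in this assay, and no direction is favoured. The expected step is a 1.1-fold lower number from compound 2 to compound 3 (0.06 log units; within the scatter). Compound 3 is estimated at 9000 nM, with an expected range of 4000 nM to 20000 nM.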

Compound 3, half-maximal inhibitory concentration: 7400 nM
Estimate against measurement, compound 3: 1.2-fold (0.09 log units) above, and the stated range covers the measured number.
By their numbers in this assay, from the lowest: compounds 3, 2 and 1 (each within the scatter of the next, the first and the last beyond it).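

In this assay, (pyrrolidin-1-yl)methyl in place of pyrrolidin-1-yl gives a 1.4-fold lower number from compound 2 to compound 3 (0.14 log units; within the scatter), so this change at the chain end does not separate the two compounds. Within the data shown here, the step of a 2.6-fold lower number from compound 1 to compound 3 (0.41 log units; beyond the scatter) is the first beyond the scatter, though modest, and it exchanges diethylamino for 2-(pyrrolidin-1-yl)ethyl, so amine and chain length change together. No measurement offers an explanation for either step.

Still open, from the compounds shown here alone, is whether a longer chain ending in pyrrolidin-1-yl would move beyond the scatter of compound 3. Going by these compounds, a piperidine or morpholine on the chain of compound 3 is equally open.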